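A few compounds are considered here, and "the series" means these few. Any claim that something is new, unique, unknown or untested is made for them only; others in the source may bear on it.

Compound 1 `COC(=O)c1ccc(-c2cn(CCCC(=O)Nc3ccc(C)cc3)nn2)cc1` and compound 2 `Cc1ccc(NC(=O)CCCn2cc(-c3ccc(C(F)(F)F)cc3)nn2)cc1` share one core and differ in a single spot: trifluoromethyl in place of methoxycarbonyl on an aromatic carbon. In a functional assay on MDA-MB-231 cells (Homo sapiens) for inhibition, read by MTT assay, with a stated time of 72 h (a higher number here means a weaker inhibitor, a lower number a stronger inhibitor), compound 1 gives 2700 nM, and compound 2 gives 2300 nM, so this change made a 1.2-fold lower number from compound 1 to compound 2 (0.07 log units; within the scatter). Compound 3 `COC(=O)c1ccc(-c2cn(CCCC(=S)Nc3ccc(C)cc3)nn2)cc1` is built on a different core; how the two cores differ is not broken down here. In this assay compound 3 reports only a limit of the assay and not a number, > 100000 nM, the point (the limit of > 100000 nM in this assay, at which 1 of the 3 values shown sits). Compound 4 `Cc1ccc(NC(=S)CCCn2cc(-c3ccc(C(F)(F)F)cc3)nn2)cc1` is not yet measured. It stands to compound 3 as compound 2 stands to compound 1, the same change at the same place: trifluoromethyl in place of methoxycarbonyl on an aromatic carbon. On the core of compound 1 this change moved the value by a 1.2-fold lower number from compound 1 to compound 2 (0.07 log units; within the scatter), a step within the scatter. On the core of compound 3 a similarly small step is expected, which would leave compound 4 at or near the limit that compound 3 reached. Compound 4 is therefore expected to give 150000 nM, somewhere between 60000 nM and 400000 nM. That would mean an estimated step that the limit leaves unreadable from compound 3 to compound 4.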

Compound 4, half-maximal inhibitory concentration: 83200 nM
Estimate against measurement, compound 4: 1.8-fold (0.26 log units) above; the range from low to high includes it.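

Compound 3 reports > 100000 nM in this assay, which is a limit of the assay and not a number. The swap of methoxycarbonyl for trifluoromethyl on this core can therefore be read only as a floor: an at least 1.2-fold lower number from compound 3 to compound 4 (0.07 log units; that floor lies within the scatter). This fits the idea that the change carries over from one core to the other with little effect, but it does not prove it, since the real step on the core of compound 3 could be small or much larger: the same change on two cores in this assay, a 1.2-fold lower number (0.07 log units; within the scatter) from compound 1 to compound 2 and an at least 1.2-fold lower number (0.07 log units; that floor lies within the scatter) from compound 3 to compound 4; the limit leaves it open whether they differ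

The compounds shown test only this one swap, on one pair of compounds per core, so it remains open whether other groups at the same place, such as a nitrile, a carboxylic acid or an amine, would act alike on both cores. On these data alone, it is also open whether a longer chain between the two ends of the molecule would alter the values seen here for compound 2 and compound 4.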